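A few compounds are considered here, and "the series" means these few. Any claim that something is new, unique, unknown or untested is made for them only; others in the source may bear on it.

Three compounds have so far been measured in a functional assay on CRL2813 cells (Homo sapiens) for cytotoxicity, read by sulforhodamine B assay, with a stated time of 5 days; on this read-out higher numbers stand for weaker inhibition and lower numbers for stronger inhibition:

compound 1 `O=C(Nc1cccc(C(F)(F)F)c1)N[C@H]1CC[C@H](Oc2ccc(Cl)cc2)CC1`: 2000 nM
compound 2 `O=C(Nc1ccccc1F)N[C@H]1CC[C@H](Oc2ccc(F)cc2)CC1`: 17500 nM
compound 3 `O=C(Nc1cccc(C(F)(F)F)c1)N[C@H]1CC[C@H](O)CC1`: a limit, > 20000 nM

Of the two plain numbers, compound 2 gives the highest, 17500 nM, and so the weaker inhibition of the pair. Compound 1 gives 2000 nM, a clearly lower number. For compound 3 only a limit is known, > 20000 nM, sitting at the limit of > 20000 nM in this assay, at which 1 of the 3 values shown sits. Among the measured compounds shown here, the one step between measured compounds that differ in a single place is an at least 10-fold higher number from compound 1 to compound 3 (1.00 log units; beyond the scatter); that step concerns the oxygen on a saturated carbon, not the amide-type nitrogen.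

Compound 4 `O=C(Nc1ccc(F)cc1)N[C@H]1CC[C@H](Oc2ccc(F)cc2)CC1` has not yet been measured. Its change from compound 2 is 4-fluorophenyl in place of 2-fluorophenyl on an amide-type nitrogen. For the measured compounds named here, no measured step touches the group on the amide-type nitrogen, so the data give no guide to direction or size for this change. The number for compound 4 is therefore expected to stay close to that of compound 2, with a step of no change at the digits printed from compound 2 to compound 4 (within the scatter), none beyond the scatter. Compound 4 is estimated at 17500 nM, within a range from 6000 nM to 40000 nM, and this assay may well report only a limit for it.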

Compound 4, half-maximal inhibitory concentration: 20000 nM
Estimate against measurement, compound 4: 1.1-fold (0.06 log units) below; the range from low to high includes it.
By their numbers in this assay, from the lowest: compound 1; then compounds 2 and 4 (each within the scatter of the next).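

In this assay, replacing 2-fluorophenyl with 4-fluorophenyl on the amide-type nitrogen gives a 1.1-fold higher number from compound 2 to compound 4 (0.06 log units; within the scatter). Among the compounds shown here, the only earlier step concerned the oxygen on a saturated carbon, so this is the first direct look at the other end of the molecule, and for this pair the place of the fluorine on the ring makes no readable difference. Any further loss of inhibition would have little room to show, however, because compound 3 already reaches a limit of the assay, and that limit lies just beyond the numbers for this pair: the limit of > 20000 nM in this assay, at which 1 of the 4 values shown sits.

Compound 1 differs from compound 2 in two places, its trifluoromethyl group and its chlorine, so the compounds shown cannot say which of these goes with its lower number, or whether either does so alone. From the compounds shown here alone, it also remains open whether a group of a different kind on this ring, such as a nitrile, a methoxy group or an amine, would move the number at all, and whether the fluorine swap would behave the same way in the core of compound 1.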